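Compound 1 to compound 4: an expected step

The compounds below may be only part of what the source reports. "The series", "measured", "known", "first", "only" and "open" are said of these compounds alone.

Going by the values given here, in a functional assay on KARPAS-422 cells (Homo sapiens) for antiproliferative activity, read by resazurin assay, with a stated time of 72 h (a lower number here means a stronger inhibitor, a higher number a weaker inhibitor), compound 1 (`COc1cc(C)[nH]c(=O)c1CN1CCc2c(Cl)cc(-c3c(C)noc3C)c(Cl)c2C1=O`) gives 27 nM as the only single number in this small set. Compound 2 (`COC(c1cc(Cl)c2c(c1Cl)C(=O)N(Cc1c(C)cc(C)[nH]c1=O)CC2)C1CCN(C2COC2)CC1`) gives 2260 nM; 25 nM (2 entries) with its entries far apart. Compound 3 (`COC(c1cc(Cl)c2c(c1Cl)C(=O)N(Cc1c(C)cc(C)[nH]c1=O)CC2)C1CCN(C(=O)CO)CC1`) gives 3140 nM; 21 nM (2 entries) with the same kind of spread. Among the compounds with values here, the value of compound 1 falls inside the span of each, so neither offers a firm comparison, and no two measured compounds differ in one place only.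

Compound 4 (`COc1cc(C)[nH]c(=O)c1CN1CCc2c(Cl)cc([C@@H](O)C3COC3)c(Cl)c2C1=O`) keeps the core of compound 1 and differs at one place (a group of 6 heavy atoms (4 carbon, 2 oxygen; one four-membered non-aromatic ring with 1 hetero atom) in place of a group of 7 heavy atoms (5 carbon, 1 nitrogen, 1 oxygen; one five-membered aromatic ring with 2 hetero atoms), on an aromatic carbon). The 3,5-dimethyl-1,2-oxazol-4-yl group leaves, and the group that enters, with its four-membered non-aromatic ring, has 1 defined stereocentre.

Within the data shown here, no measured step covers this swap, so the expectation starts from compound 1 at 27 nM and remains rough. Compound 2 at 2260 nM; 25 nM (2 entries) and compound 3 at 3140 nM; 21 nM (2 entries) also lack the five-membered aromatic ring, and their spread calls for a wide expected range. The estimated step of a 2.2-fold higher number from compound 1 to compound 4 (0.35 log units; beyond the scatter) points to a moderately weaker compound, probably just beyond the usual scatter. The expected value for compound 4 is 60 nM within an estimated range of 15 nM to 300 nM for this series.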

Compound 4, half-maximal inhibitory concentration in the KARPAS-422 assay: 10600 nM
Beside the measured number, compound 4's estimate is 180-fold (2.25 log units) below it; the whole stated range lies below it.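

Going by these compounds alone, in the KARPAS-422 assay, compound 1 gives 27 nM and compound 4 gives 10600 nM; replacing the 3,5-dimethyl-1,2-oxazol-4-yl group with the group carrying the four-membered non-aromatic ring gives a 390-fold higher number from compound 1 to compound 4 (2.59 log units; beyond the scatter) and is the first step at this position that can be read on its own. This aromatic carbon, ortho to a chloro group, is therefore far from indifferent to what it carries, which compounds 2 and 3 could not show, since each differs from compound 4 in more than one place. In a physicochemical assay for solubility, measured as kinetic solubility (a lower number here means a less soluble compound, a higher number a more soluble compound), compound 1 gives 384000 nM and compound 4 gives 582000 nM; the same change gives a 1.5-fold higher number from compound 1 to compound 4 (0.18 log units; within the scatter) and so does not separate the pair in solubility.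

The compounds shown offer no cause for the large step in the antiproliferative read-out. Still open, as far as these compounds go, are whether the loss follows from removing the five-membered aromatic ring or from the entering group itself, whether the opposite configuration at the stereocentre behaves alike, and whether a phenyl, a 1-methylpyrazol-4-yl group, an amine or a carboxylic acid on this carbon would stay close to compound 1.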